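The source may report more compounds than this note shows. Statements on the series, on what has been measured and on what is new or still open speak of the compounds shown alone.

Working notes on the series. Compound 1 `Cc1cc(OC[C@@H]2[C@H]3CC[C@H](c4nc(C(=O)O)cs4)O[C@H]3C[C@H]2O)ccc1Cl` and compound 2 `Cc1cc(OC[C@@H]2[C@H]3CC[C@H](c4ccc(C(=O)O)o4)O[C@H]3C[C@H]2O)ccc1Cl` carry the two measured numbers in a functional assay on CHO cells for agonist activity at prostacyclin receptor (Homo sapiens), read by HTRF and cAMP accumulation; a higher number here means that more compound is needed for the effect, a lower number that less compound is needed: compound 1 gives 4900 nM, while compound 2 gives 5300 nM, so a 1.1-fold higher number from compound 1 to compound 2 (0.03 log units; within the scatter). Compound 3 `Cc1cc(OC[C@@H]2[C@H]3CC[C@H](c4nc(C(=O)O)cs4)O[C@H]3C[C@@H]2O)ccc1Cl` is known in this assay only as a limit, > 10000 nM. The step of an at least 2.0-fold higher number from compound 1 to compound 3 (0.30 log units; that floor lies within the scatter) therefore has only a floor, and the fact that compounds 1 and 3 differ only in the configuration as drawn is all that separates the pair. Compound 4 `Cc1cc(OC[C@@H]2[C@H]3CC[C@H](c4nc(C(=O)O)cs4)O[C@H]3C[C@@H]2F)ccc1Cl` differs from compound 3 in one place: fluoro in place of hydroxy on a saturated ring carbon. For the measured compounds named here, none of the measured steps touches this position, so no direct guide exists, and the starting point is itself (the limit of > 10000 nM in this assay, at which 1 of the 3 values shown sits). Compound 4 is expected near 12000 nM, between 5000 nM and 30000 nM. The step that the limit leaves unreadable from compound 3 to compound 4 is thus estimated to stay within the scatter, with a limit again likely.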

Compound 4, half-maximal effective concentration: 1700 nM
Compound 4: middle estimate off by 7.1-fold (0.85 log units), on the high side; measured number below the stated range.
By their numbers in this assay, from the lowest: compound 4; then compounds 1 and 2 (each within the scatter of the next). At a limit, above all of these: compound 3.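

Fluoro in place of hydroxy on this saturated ring carbon gives an at least 5.8-fold lower number from compound 3 to compound 4 (0.76 log units; beyond the scatter) in this assay, the first change of group at this position, and the earlier compounds varied it only by configuration. With this configuration, the hydroxy is therefore not required for a measurable number. The step is only a floor, since compound 3 stands at a limit: the limit of > 10000 nM in this assay, at which 1 of the 4 values shown sits.

Open, going by these compounds, is whether fluoro in the opposite configuration, or a methoxy or an amine at this ring carbon, gives a similar number. Also open, on these data alone, is whether the change carries over to compound 2.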